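A few compounds are considered here, and "the series" means these few. Any claim that something is new, unique, unknown or untested is made for them only; others in the source may bear on it.

Compound 1 `S=C(Nc1ccccc1)OCCc1ccccn1`: in an ADME assay on MT4 cells (Homo sapiens) for cytotoxicity, read by MTT assay (on this read-out higher numbers stand for lower toxicity in this test and lower numbers for higher toxicity in this test), compound 1 gives > 100000 nM, which is a limit of the assay and not a number.
Compound 2 `S=C(Nc1ccccc1Cl)OCCc1ccccn1`: compound 2 gives > 100000 nM, also a limit of the assay.
Compound 3 `Cc1ccc(NC(=S)OCCc2ccccn2)cc1`: compound 3 gives 75000 nM.

Among the measured compounds shown here, compound 3 thus holds the only number so far; the other two values sit at a limit of the assay, as the limit of > 100000 nM in this assay, at which 2 of the 3 values shown sit, shows. For the measured compounds named here, the step of an at least 1.3-fold lower number from compound 1 to compound 3 (0.12 log units; that floor lies within the scatter) is the one readable step, and its floor lies within the scatter. The step that the two limits leave unreadable from compound 1 to compound 2 cannot be sized, since both ends are limits.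

Compound 4 `S=C(Nc1ccc(I)cc1)OCCc1ccccn1` is the next compound. It differs from compound 3 as follows: iodo in place of methyl on an aromatic carbon. Going by the values given here, no measured step exchanges methyl for iodo, and the one step that introduces a halogen, from compound 1 to compound 2, is unreadable. Among the compounds with values here, the single readable step, from compound 1 to compound 3, is small at its floor. On this basis no step beyond the scatter is expected from compound 3 to compound 4 in this assay, with a real chance that the result is again only a limit.

Compound 4 is therefore estimated at 75000 nM, with a range from 30000 nM to 150000 nM, meaning an expected step of no change at the digits printed from compound 3 to compound 4 (within the scatter).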

Compound 4, half-maximal cytotoxic concentration: 34000 nM
Estimate against measurement, compound 4: 2.2-fold (0.34 log units) above, within the range that was stated.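

In this assay, among the compounds shown here, the exchange of methyl for iodo, para to a large group, gives a 2.2-fold lower number from compound 3 to compound 4 (0.34 log units; beyond the scatter) and so supplies the first step between two numbers that clears the scatter. Set against hydrogen at the same place, iodo gives an at least 2.9-fold lower number from compound 1 to compound 4 (0.46 log units; beyond the scatter), whereas the floor of the methyl step from the same starting compound stayed within the scatter, so this place now shows that a single exchanged group can move the read-out towards higher toxicity in this test. The size of that second step remains a floor, because compound 1 stands at a limit and not at a number: the limit of > 100000 nM in this assay, at which 2 of the 4 values shown sit.

From the compounds shown here alone, whether the lower number belongs to iodo alone or to halogens in general at this place stays open, since only iodo is seen there and the step that brings in chloro cannot be read. Equally open, going by these compounds, is how a bromo or fluoro group, an amine or a carboxylic acid at the same place would compare with compound 4, including whether any of them would raise the number rather than lower it.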